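An ethynylphenyl group replaces 3-chloro-2-fluorophenyl

The source may report more compounds than this note shows. Statements on the series, on what has been measured and on what is new or still open speak of the compounds shown alone.

Compound 1 `O=C(/C=C/c1ccccc1)Nc1cc2c(Nc3ccc(Cl)c(Cl)c3)ncnc2s1` gives 15300 nM
Compound 2 `O=C(/C=C/c1ccccc1)Nc1cc2c(Nc3cccc(Cl)c3F)ncnc2s1` gives 93900 nM

In a functional assay on MCF7 cells (Homo sapiens) for antiproliferative activity, read by MTT assay, with a stated time of 48 h (a higher number here means a weaker inhibitor, a lower number a stronger inhibitor), compound 2 holds the higher of the two numbers, at 93900 nM. Compound 3 `C#Cc1cccc(Nc2ncnc3sc(NC(=O)/C=C/c4ccccc4)cc23)c1` differs from it as follows: 3-ethynylphenyl in place of 3-chloro-2-fluorophenyl on a nitrogen on an aromatic ring. Going by the values given here, only one measured step bears on this place, a 6.1-fold higher number from compound 1 to compound 2 (0.79 log units; beyond the scatter), which is modest but beyond the scatter. With compound 2 at the weak end of this short series, a modest move back toward lower numbers is expected, though one step is thin evidence. The expected change is a 2.7-fold lower number from compound 2 to compound 3 (0.43 log units; beyond the scatter). For compound 3 the estimated value is 35000 nM, with an expected range of 10000 nM to 100000 nM.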

Compound 3, half-maximal inhibitory concentration: 38400 nM
Estimate against measurement, compound 3: 1.1-fold (0.04 log units) below; measured number inside the range.
By their numbers in this assay, from the lowest: compound 1; then compound 3; then compound 2.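

Moving to 3-ethynylphenyl gives a 2.4-fold lower number from compound 2 to compound 3 (0.39 log units; beyond the scatter) in this assay and shows that a ring carrying no halogen can still improve on a halogenated one at this place on the nitrogen. The same group also gives a 2.5-fold higher number from compound 1 to compound 3 (0.40 log units; beyond the scatter) in this assay so it falls between the two halogenated rings, and halogen presence alone does not order these three compounds. Nothing available explains this order. Still open, as far as these compounds go, is how a methoxy group or an amine on this phenyl ring would compare with 3,4-dichlorophenyl.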